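A few compounds are considered here, and "the series" means these few. Any claim that something is new, unique, unknown or untested is made for them only; others in the source may bear on it.

Of the compounds shown here, three of one series have so far been measured in a functional assay on cells (Panel leukemia (Carcinoma cell lines), Homo sapiens) for antiproliferative activity; a higher number here means a weaker inhibitor of growth, a lower number a stronger inhibitor of growth. Compound 1 `COc1cccc(-c2nn(-c3ccccc3)cc2-c2ccnc(NCCNC(=O)Nc3ccc(Cl)c(Cl)c3)c2)c1` gives 3400 nM, compound 2 `COc1cccc(-c2nn(-c3ccccc3)cc2-c2ccnc(NCCCNC(=O)Nc3ccc(Cl)c(Cl)c3)c2)c1` gives 2310 nM, and compound 3 `O=C(NCCCNc1cc(-c2cn(-c3ccccc3)nc2-c2cccc(O)c2)ccn1)c1ccccc1` gives 1620 nM. Compound 3 carries the lowest of the three numbers; its gap to compound 2 lies within the scatter, while its gap to compound 1 lies beyond it. Compound 4 `O=C(NCCCNc1cc(-c2cn(-c3ccccc3)nc2-c2cccc(O)c2)ccn1)c1ccc(F)cc1` differs from compound 3 in one place: fluoro in place of hydrogen on an aromatic carbon. For the measured compounds named here, no step of this kind exists among the measured compounds, so the change is expected to move this assay little, and the estimated shift a 1.1-fold lower number from compound 3 to compound 4 (0.03 log units; within the scatter) is expected to stay within the scatter with no clear direction. Compound 4 is accordingly expected to give about 1500 nM, within a range of 700 nM to 3500 nM.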

Compound 4, concentration for 50% growth inhibition: 1980 nM
The estimate for compound 4 lay 1.3-fold (0.12 log units) below the measured number; low and high end bracket the measured number.
By their numbers in this assay, from the lowest: compounds 3, 4, 2 and 1 (each within the scatter of the next, the first and the last beyond it).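

For the compounds shown here, the step from benzoyl to (4-fluorophenyl)carbonyl, a 1.2-fold higher number from compound 3 to compound 4 (0.09 log units; within the scatter), is the first change in one place, and it shows that in this assay fluoro at this aromatic carbon, para to a large group, leaves the number within the scatter. No measurement on hand explains this step.

Going by these compounds, whether a larger group on the same carbon, such as methoxy, an amine or a carboxylic acid, would move the number beyond the scatter stays open. So does whether fluoro at another carbon of this ring would do so.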